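A few compounds are considered here, and "the series" means these few. Any claim that something is new, unique, unknown or untested is made for them only; others in the source may bear on it.

Two pairs of compounds share one change: the swap of a nitro group for an amino group on an aromatic carbon. The first pair is measured. Compound 1 `COc1ccc(-n2ccnc2-c2cc(OC)c(OC)c(OC)c2)cc1[N+](=O)[O-]` carries the nitro group, and compound 2 `COc1ccc(-n2ccnc2-c2cc(OC)c(OC)c(OC)c2)cc1N` carries the amino group in the same place, with the change counted as amino in place of nitro on an aromatic carbon. In a functional assay on T47D cells (Homo sapiens) for antiproliferative activity, read by MTT assay, with a stated time of 72 h (a higher number here means a weaker inhibitor, a lower number a stronger inhibitor), compound 1 gives 10000 nM, while compound 2 gives 500 nM, so the swap brought a 20-fold lower number from compound 1 to compound 2 (1.30 log units; beyond the scatter).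

The second pair rests on a different core. Compound 3 `COc1ccc(NC(=O)c2cc(OC)c(OC)c(OC)c2)cc1[N+](=O)[O-]` carries the nitro group on that core; how its core differs from the core of compound 1 is not broken down here. In this assay compound 3 gives 34500 nM, the highest number of the three measured compounds. Compound 4 `COc1ccc(NC(=O)c2cc(OC)c(OC)c(OC)c2)cc1N` is compound 3 with the same change, counted as amino in place of nitro on an aromatic carbon, and it has not yet been measured in this assay.

The surroundings of the changed carbon read the same in both pairs, so the same change is expected to act in the same direction. The step from compound 3 to compound 4 is estimated at a 17-fold lower number from compound 3 to compound 4 (1.24 log units; beyond the scatter), set beside the measured step because that step was a 20-fold lower number from compound 1 to compound 2 (1.30 log units; beyond the scatter), with a wider margin because the core is different. Compound 4 is therefore expected to give about 2000 nM in this assay, most likely between 500 nM and 15000 nM.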

Compound 4, half-maximal inhibitory concentration: 50400 nM
Compound 4: the middle estimate sits 25-fold (1.40 log units) below what was measured, and the stated range ends below it.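

In this assay, placing an amino group where the nitro group stood on the second core gave a 1.5-fold higher number from compound 3 to compound 4 (0.16 log units; within the scatter), so the values of this pair cannot be told apart, and the large gain seen on the core of compound 1 does not appear here. The swap therefore does not carry from one core to the other in this series, even though the changed carbon has the same immediate surroundings in both pairs, and the gap between the two steps is larger than repeated measurements would explain: the same change on two cores in this assay, a 20-fold lower number (1.30 log units; beyond the scatter) from compound 1 to compound 2 and a 1.5-fold higher number (0.16 log units; within the scatter) from compound 3 to compound 4, 29-fold (1.47 log units) apart, beyond the scatter of two such steps. Within the data shown here, with only two pairs, this does not show which feature of the cores decides the outcome, nor how the swap would behave on any third core.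

On these data alone, it remains open whether another group on the same carbon, such as a hydroxyl, a fluorine or an acetamide, would follow the pattern of the core of compound 1 or that of compound 3. Also open, as far as these compounds go, is whether replacing the methoxy group on the changed ring with an ethoxy group or a chlorine would alter the step on either core.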